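This account rests on a few compounds, and the source may have more. Where it says the series, first, only, none or still open, it means among the compounds named here.

Measured compounds in this series:
- compound 2 `Oc1ccc(-c2cc(-c3ccccc3)nc(-c3ccccc3Cl)c2)cc1`: 2800 nM
- compound 3 `Oc1ccc(-c2cc(-c3cccs3)nc(-c3ccccc3Cl)c2)cc1`: 4190 nM
- compound 1 `Oc1ccc(-c2cc(-c3ccccn3)nc(-c3ccccc3Cl)c2)cc1`: "not determined" (no result reported) in a functional assay on DU-145 cells (Homo sapiens) for cytotoxicity, read by CCK-8 assay and cell counting, with a stated time of 2 days; a lower number here means a stronger inhibitor, a higher number a weaker inhibitor

Compound 3 holds the highest of the two numbers available in this assay. Its nearest neighbour is compound 2, and the step of a 1.5-fold higher number from compound 2 to compound 3 (0.18 log units; within the scatter) lies within the scatter, so the two compounds cannot be ordered on these data. Compound 1 contributes no number.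

Compound 4 `Oc1ccc(-c2cc(-c3ccco3)nc(-c3ccccc3Cl)c2)cc1` is the next member. The change from compound 3 is furan-2-yl in place of thiophen-2-yl on an aromatic carbon. Among the compounds with values here, the one measured step that bears on this position is a 1.5-fold higher number from compound 2 to compound 3 (0.18 log units; within the scatter), an exchange of the same aromatic carbon's substituent that stayed within the scatter. Within the data shown here, with only one step at this position, and that one small, the expectation for compound 4 is a step of a 1.1-fold higher number from compound 3 to compound 4 (0.03 log units; within the scatter) that again stays within the scatter, with no direction preferred. Among the measured compounds shown here, on that basis compound 4 is estimated at 4500 nM, with a range from 1800 nM to 11000 nM, the width reflecting that the series gives no measured step for a furan-2-yl group.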

Compound 4, half-maximal inhibitory concentration: 5300 nM
Estimate against measurement, compound 4: 1.2-fold (0.07 log units) below, within the range that was stated.
By their numbers in this assay, from the lowest: compounds 2, 3 and 4 (each within the scatter of the next).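

Working notes on the position next to the ring nitrogen: in this assay, the exchange of thiophen-2-yl for furan-2-yl gives a 1.3-fold higher number from compound 3 to compound 4 (0.10 log units; within the scatter), so a second five-membered aromatic ring with one hetero atom, now holding oxygen in place of sulfur, gives no step that can be told from the scatter. The series now also has a direct comparison of furan-2-yl with phenyl at this carbon, a 1.9-fold higher number from compound 2 to compound 4 (0.28 log units; within the scatter), which means that phenyl, thiophen-2-yl and furan-2-yl cannot be ordered in this assay on these data, and none of the steps among them leaves the scatter. No evidence at hand bears on this result.

All the steps shown concern this one aromatic carbon, so it remains open whether a non-aromatic substituent there, such as a dimethylamino group or a longer alkyl chain, would give a step beyond the scatter. As far as these compounds go, the contributions of the 2-chlorophenyl and 4-hydroxyphenyl groups also remain open, for example what a methoxy group or a carboxylic acid in place of the hydroxyl would do to the number.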